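Triazole series: aryl swap on ring nitrogen, cytotoxicity read-out

The source may report more compounds than this note shows. Statements on the series, on what has been measured and on what is new or still open speak of the compounds shown alone.

Measured so far:
compound 1, `CC(C)c1ccc(-n2nc(-c3ccc(C(F)(F)F)cc3O)nc2-c2ccccc2O)cc1`: 69.7%
compound 2, `Oc1cc(C(F)(F)F)ccc1-c1nc(-c2ccccc2O)n(-c2ccc(Br)cc2)n1`: 69.4%

In a functional assay on PC-12 cells (Rattus norvegicus) for cytotoxicity, read by MTT assay, with stated times of 2 h and 24 h, tested at 1 uM (on this read-out higher numbers stand for a stronger effect at the one concentration tested and lower numbers for a weaker effect), compound 1 gives 69.7%, and in this assay compound 2 gives 69.4%. Compound 2 holds the lowest of the two numbers, but its nearest neighbour, compound 1, sits within the scatter, so the two show no order. Going by the values given here, the only measured step, a number 0.3 percentage points lower from compound 1 to compound 2 (within the scatter), is bromo in place of isopropyl on an aromatic carbon and is within the scatter.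

Compound 3, `Oc1cc(C(F)(F)F)ccc1-c1nc(-c2ccccc2O)n(-c2cc(F)cc(F)c2)n1`, is not yet measured. Its difference from compound 2: 3,5-difluorophenyl in place of 4-bromophenyl on an aromatic nitrogen. Among the compounds with values here, the one measured step bears on it only loosely, as it too changes the group attached to the same aromatic nitrogen; that step was flat. Compound 3 is therefore expected to show no step beyond the scatter in this assay, the expected step being a number 2.4 percentage points lower from compound 2 to compound 3 (within the scatter). The estimate for compound 3 in this assay is 67%, expected between 55% and 78%.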

Compound 3, a percentage reported as activity, at one concentration (the size of the read-out at that concentration, not a potency): 75.5%
Estimate against measurement, compound 3: 8.5 percentage points below, within the range that was stated.
By their numbers in this assay, from the lowest: compounds 2, 1 and 3 (each within the scatter of the next).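

Replacing the single substituent of 4-bromophenyl with the two fluorines of 3,5-difluorophenyl on the aromatic nitrogen leaves the read-out in this assay flat, with a number 6.1 percentage points higher from compound 2 to compound 3 (within the scatter) and a number 5.8 percentage points higher from compound 1 to compound 3 (within the scatter) as the two steps. Compounds 1 and 2 covered only 4-isopropylphenyl and 4-bromophenyl, whereas compound 3 extends the flat picture to a phenyl group substituted in two other ring places, so among these three compounds the substitution pattern on this phenyl does not separate the values. No supporting data are available to account for this result.

From the compounds shown here alone, it remains open whether a group other than a substituted phenyl at this nitrogen, such as a pyridine ring or a short alkyl chain, or an amine or carboxylic acid on the phenyl, would give a step beyond the scatter. With a single tested concentration, these values also leave potency across the series unresolved.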